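This account rests on a few compounds, and the source may have more. Where it says the series, first, only, none or still open, it means among the compounds named here.

Compound 1 `COc1ccc(CNc2nc3cc(N)cc(N)c3nc2-c2ccccc2)cc1OC`: 29500 nM in a functional assay on HOP-92 cells (Homo sapiens) for inhibition, read by sulforhodamine B assay, with a stated time of 48 h; a lower number here means a stronger inhibitor of growth, a higher number a weaker inhibitor of growth.
Compound 2 `Nc1cc(N)c2nc(-c3ccccc3)c(NCc3ccc(F)cc3)nc2c1`: 6920 nM in this assay.

Among the measured compounds shown here, of these two numbers compound 2 holds the lower one; its only neighbour is compound 1, separated from it by a 4.3-fold lower number from compound 1 to compound 2 (0.63 log units; beyond the scatter). Compound 3 `COc1ccc(CNc2nc3cc(N)cc(N)c3nc2-c2ccccc2)cc1` has not yet been measured in this assay; it differs from compound 2 by methoxy in place of fluoro on an aromatic carbon. For the measured compounds named here, the one measured step that bears on this change is a 4.3-fold lower number from compound 1 to compound 2 (0.63 log units; beyond the scatter), in which a 4-fluorophenyl took the place of a 3,4-dimethoxyphenyl and the number fell. The change to compound 3 goes part of the way back, returning one methoxy group in place of the fluoro. Because compound 2 gives 6920 nM and only part of that earlier change is undone, compound 3 is expected to show a moderately higher number, estimated at 12000 nM with a range of 5000 nM to 30000 nM. The expected step is a 1.7-fold higher number from compound 2 to compound 3 (0.24 log units; within the scatter), of a size near the edge of the usual scatter.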

Compound 3, concentration for total growth inhibition: 37200 nM
The estimate for compound 3 lay 3.1-fold (0.49 log units) below the measured number; measured number outside the range, above it.
By their numbers in this assay, from the lowest: compound 2; then compounds 1 and 3 (each within the scatter of the next).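

Swapping fluoro for methoxy on this aromatic carbon, para to a large group, is enough on its own to open the gap in this assay: there is a 5.4-fold higher number from compound 2 to compound 3 (0.73 log units; beyond the scatter). The second methoxy of compound 1 does not separate it from compound 3, with a 1.3-fold higher number from compound 1 to compound 3 (0.10 log units; within the scatter), so among these three compounds the gap follows the group at this one carbon, and compounds 1 and 3 stand together against compound 2. Nothing given here accounts for this difference in measured terms.

From the compounds shown here alone, it remains open whether the lower number of compound 2 belongs to fluoro itself or only to the absence of methoxy at this carbon. A chloro or a methyl group at the same carbon would help separate those two readings.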